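From 3,4-Dimethoxyphenyl to 3,4-Dihydroxyphenyl: an Expected Measurement

The source may hold more compounds than are shown below. What is called first, only, known or untested is meant among the compounds shown, and "the series" means these compounds.

Of the compounds shown here, two have been measured in an assay for binding affinity to Apoptosis regulator Bcl-2 (Homo sapiens), read by fluorescence polarization, with stated times of 30 min and 20 min, tested at 100 uM; on this read-out higher numbers stand for more inhibition at the one concentration tested (going by the name of the read-out) and lower numbers for less inhibition. Compound 1 `COc1ccc(Oc2ccccc2-c2ccsc2S(=O)(=O)N2CCN(C(=S)Nc3ccc([N+](=O)[O-])cc3)CC2)cc1OC` gives 16% in this assay, the higher of the two numbers. Compound 2 `COc1ccc(Oc2ccccc2-c2ccsc2S(=O)(=O)N2CCN(C(=O)Nc3ccc(F)cc3)CC2)cc1OC` gives 15%. Among the compounds with values here, the one measured step, a number 1 percentage points lower from compound 1 to compound 2 (within the scatter), exchanges the group on the amine nitrogen in the ring and leaves the rest of the shared core as it is.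

Compound 3 `O=[N+]([O-])c1ccc(NC(=S)N2CCN(S(=O)(=O)c3sccc3-c3ccccc3Oc3ccc(O)c(O)c3)CC2)cc1` differs from compound 1 at another place: 3,4-dihydroxyphenyl in place of 3,4-dimethoxyphenyl on an oxygen on an aromatic ring. Within the data shown here, no measured step touches the group on this oxygen on an aromatic ring, so none bears directly on the change from compound 1 to compound 3. Among the measured compounds shown here, the only guidance is that the single change tried so far moved the read-out by no more than the scatter. The expected step is therefore no change at the digits printed from compound 1 to compound 3 (within the scatter), none beyond the scatter. Compound 3 is estimated at 16% in this assay, with a range from 4% to 32%.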

Compound 3, a percentage reported as inhibition, at one concentration (the size of the read-out at that concentration, not a potency): 31%
The estimate for compound 3 lay 15 percentage points below the measured number, and the stated range covers the measured number.
By their numbers in this assay, from the lowest: compounds 2 and 1 (each within the scatter of the next); then compound 3.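

In this assay, 3,4-dihydroxyphenyl in place of 3,4-dimethoxyphenyl on an oxygen on an aromatic ring gives a number 15 percentage points higher from compound 1 to compound 3 (beyond the scatter). Within the data shown here, this is the first step to pass the scatter, and it shows that the read-out responds to the group at this place, which the earlier step at the amine nitrogen in the ring could not show. No measurement shown explains the rise.

The compounds leave open whether both hydroxy groups are needed, or whether a phenyl carrying one hydroxy and one methoxy group would give a similar number. They also leave open how a carboxylic acid or an amine on this ring would read, and whether the same exchange would raise the number on the core of compound 2.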